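Piperidin-1-yl in place of pyrrolidin-1-yl: expected clearance

This account rests on a few compounds, and the source may have more. Where it says the series, first, only, none or still open, it means among the compounds named here.

Compound 1 `CN(C)c1ccc2cc(-c3cn(C)c4ccccc34)c(N)nc2c1`: 210 mL/min/kg
Compound 2 `Cn1cc(-c2cc3ccc(N4CCCC4)cc3nc2N)c2ccccc21`: > 500 mL/min/kg

Both results come from an ADME assay on microsomes from liver (Mus musculus) for metabolic stability, read by HPLC, with a stated time of 4 h; on this read-out higher numbers stand for fast clearance and lower numbers for slow clearance. The result for compound 2 is a limit of the assay and not a number. Compound 2 stands at the limit of > 500 mL/min/kg in this assay, at which 1 of the 2 values shown sits. For the measured compounds named here, the only measured step is an at least 2.3-fold higher number from compound 1 to compound 2 (0.37 log units; beyond the scatter), with pyrrolidin-1-yl in place of dimethylamino on an aromatic carbon. Compound 3 `Cn1cc(-c2cc3ccc(N4CCCCC4)cc3nc2N)c2ccccc21` carries piperidin-1-yl in place of pyrrolidin-1-yl on an aromatic carbon. The measured step concerns a different exchange at this place on the shared core, so it bears on the new change only indirectly. It offers no size to carry over, and no step beyond the scatter is expected in this assay. The expected change is a step that the limit leaves unreadable from compound 2 to compound 3. For compound 3 the estimated clearance is 520 mL/min/kg, with an expected range of 260 mL/min/kg to 1000 mL/min/kg.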

Compound 3, clearance: 95 mL/min/kg
Compound 3: the middle estimate sits 5.5-fold (0.74 log units) above what was measured; the measured number lies below the stated range.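

In this assay the group on this aromatic carbon proves able to move the read-out sharply down as well as up: piperidin-1-yl in place of pyrrolidin-1-yl gives an at least 5.2-fold lower number from compound 2 to compound 3 (0.72 log units; beyond the scatter). Set against dimethylamino, piperidin-1-yl also gives a 2.2-fold lower number from compound 1 to compound 3 (0.34 log units; beyond the scatter), so among the compounds shown a saturated ring at this place does not in itself go with the higher number, and compound 2 and compound 3 fall on opposite sides of compound 1. Going by these compounds, compound 2 stands at a limit of the assay and not at a number, so the full size of the first step stays unknown: the limit of > 500 mL/min/kg in this assay, at which 1 of the 3 values shown sits.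

The compounds shown leave open whether a ring holding a second hetero atom, such as morpholin-4-yl or 4-methylpiperazin-1-yl, would keep the lower clearance. On these data alone, how the larger ring of azepan-1-yl would read also remains open.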